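The source may hold more compounds than are shown below. What is called first, only, known or untested is meant among the compounds shown, and "the series" means these compounds.

Compound 1 `COCc1ncc2cnnc(SC)n12` gives > 48000 nM in a functional assay for inhibition, with Homo sapiens as the target (on this read-out higher numbers stand for weaker inhibition and lower numbers for stronger inhibition), and that value is a limit of the assay rather than a number. Compound 2 `CCCc1nc(C)c2cnn(CC(O)CO)c(=O)n12` likewise gives > 48000 nM in this assay, again a limit and not a number. Both values therefore sit at the same place, as the limit of > 48000 nM in this assay, at which 2 of the 2 values shown sit, shows. Compound 3 `CCCc1nc(C)c2cnn(CC)c(=O)n12` differs from compound 2 by methyl in place of 1,2-dihydroxyethyl on a saturated chain carbon bound to an aromatic nitrogen. Within the data shown here, with no measured step to lean on, compound 3 is expected to change nothing beyond the scatter, the estimated step being a step that the limit leaves unreadable from compound 2 to compound 3. Compound 3 is thus expected to give about 60000 nM, within 15000 nM to 250000 nM.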

Compound 3, half-maximal inhibitory concentration: > 48000 nM
Compound 3: only a limit was reported; the forecaster's own chance of this, stated with the estimate: 80%; the middle value lies beyond the limit too.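

Compound 2 and compound 3 both give only a limit and not a number, so no step can be read between them. How strongly any of the three compounds inhibits in this assay stays open: the limit of > 48000 nM in this assay, at which 3 of the 3 values shown sit.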